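Bis-sulfonylphenyl piperidines: amide replaced by isoxazole

The compounds below may be only part of what the source reports. "The series", "measured", "known", "first", "only" and "open" are said of these compounds alone.

Two members of the series have numbers in a functional assay on MIA PaCa-2 cells (Homo sapiens) for inhibition, read by MTT assay, with a stated time of 7 days; a higher number here means a weaker inhibitor, a lower number a stronger inhibitor. Compound 1 `CCN(CC)S(=O)(=O)c1ccc(S(=O)(=O)N2CCC[C@@H](C(=O)N(C)C(C)C)C2)cc1` gives 6200 nM in this assay. Among the measured compounds shown here, compound 2 `CCN(CC)S(=O)(=O)c1ccc(S(=O)(=O)N2CCC[C@@H](C(=O)NC3CN(S(C)(=O)=O)C3)C2)cc1` gives 2500 nM in this assay, the lowest of the two numbers; the only measured step, a 2.5-fold lower number from compound 1 to compound 2 (0.39 log units; beyond the scatter), is modest and concerns exchange of one amine on the carbonyl carbon for another. Compound 3 `CCN(CC)S(=O)(=O)c1ccc(S(=O)(=O)N2CCC[C@@H](c3cc(C)no3)C2)cc1` is not yet measured. It differs from compound 2 by 3-methyl-1,2-oxazol-5-yl in place of (1-(methylsulfonyl)azetidin-3-yl)carbamoyl on a saturated ring carbon, so the carbonyl and its amine leave entirely. For the measured compounds named here, no measured step removes the carbonyl, so the step from compound 1 to compound 2 bears on this change only in showing that the group on the saturated ring carbon shifts the number modestly. The expected step, a 2.0-fold higher number from compound 2 to compound 3 (0.30 log units; within the scatter), is therefore small and of uncertain direction, with wide bounds. Compound 3 is estimated at 5000 nM, within 1200 nM to 20000 nM.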

Compound 3, half-maximal inhibitory concentration: 4900 nM
Beside the measured number, compound 3's estimate is 1.0-fold (0.01 log units) above it; the range from low to high includes it.
By their numbers in this assay, from the lowest: compounds 2, 3 and 1 (each within the scatter of the next, the first and the last beyond it).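

In this assay, removing the carbonyl and its amine altogether gives a 2.0-fold higher number from compound 2 to compound 3 (0.29 log units; within the scatter), so at this position on the saturated ring carbon, 3-methyl-1,2-oxazol-5-yl cannot be told apart from (1-(methylsulfonyl)azetidin-3-yl)carbamoyl. The same group in place of isopropyl(methyl)carbamoyl gives a 1.3-fold lower number from compound 1 to compound 3 (0.10 log units; within the scatter), which shows that, among these three compounds, the carbonyl is not needed for a number in this range. No supporting data are available to account for these results.

From the compounds shown here alone, it remains open whether a 1,2-oxazol-5-yl without the methyl, a primary amine or a carboxylic acid at this position would give a number beyond the scatter of compound 3. Also open, going by these compounds, is whether these close numbers carry over to other cell lines.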